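This account rests on a few compounds, and the source may have more. Where it says the series, first, only, none or still open, it means among the compounds named here.

Compound 3 `C=CCOc1ccc2c(=O)c(-c3ccc(O)cc3)coc2c1` stands with the highest number of the three measured in an assay on isolated protein (Cricetulus griseus) for inhibition of aldehyde dehydrogenase, mitochondrial (Homo sapiens) (on this read-out higher numbers stand for weaker inhibition and lower numbers for stronger inhibition), giving 800 nM. Compound 1 `O=c1c(-c2ccc(O)cc2)coc2cc(OCCCCCCBr)ccc12` gives 300 nM in this assay and compound 2 `O=c1c(-c2ccc(O)cc2)coc2cc(OCCCBr)ccc12` gives 260 nM; between them the step is a 1.2-fold lower number from compound 1 to compound 2 (0.06 log units; within the scatter). Compound 4 `O=C(O)CCCCCCOc1ccc2c(=O)c(-c3ccc(O)cc3)coc2c1` is not yet measured in this assay; it differs from compound 3 by 5-carboxypentyl in place of vinyl on a saturated chain carbon bound to an oxygen on an aromatic ring. Within the data shown here, two measured steps bear on this change, both through the same position: a 2.7-fold higher number from compound 1 to compound 3 (0.43 log units; beyond the scatter) and a 3.1-fold higher number from compound 2 to compound 3 (0.49 log units; beyond the scatter). In both, moving to the short vinyl chain raised the number by a modest amount, so the longer chain in compound 4 would be expected to bring the number back toward those of compound 1 and compound 2. The carboxylic acid at the chain end has no counterpart among the measured compounds, and its effect cannot be weighed from the data shown; this widens the range. The step to compound 4 is therefore expected to be a 2.0-fold lower number from compound 3 to compound 4 (0.30 log units; within the scatter), a lowering of about the size seen in the chain steps. Compound 4 is estimated at 400 nM, with a range from 150 nM to 1200 nM.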

Compound 4, half-maximal inhibitory concentration: 9 nM
Compound 4: the middle estimate sits 44-fold (1.65 log units) above what was measured; the whole stated range lies above it.
By their numbers in this assay, from the lowest: compound 4; then compounds 2 and 1 (each within the scatter of the next); then compound 3.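

In this assay the end of the chain, rather than its length, goes with the large change: with the chain otherwise kept, carboxy in place of bromo gives a 33-fold lower number from compound 1 to compound 4 (1.52 log units; beyond the scatter), whereas the two bromo chains differ only within the scatter, at a 1.2-fold lower number from compound 1 to compound 2 (0.06 log units; within the scatter). Among these compounds, the carboxylic acid end also stands well apart from the shorter bromo chain, with a 29-fold lower number from compound 2 to compound 4 (1.46 log units; beyond the scatter), and from the short vinyl chain, with an 89-fold lower number from compound 3 to compound 4 (1.95 log units; beyond the scatter), so the modest steps among the earlier compounds gave no sign of a change of this size at this position. The compounds shown offer no independent measurement that explains why this end group has so large an effect.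

Among the compounds shown here, whether the carboxylic acid holds this level on a shorter chain such as 3-carboxypropyl, or on a longer chain than the one in compound 4, remains open. Also open, from the compounds shown here alone, is whether a methyl ester, a primary amide or a tetrazole at the same chain end would give a similar number, which would show how much of the step depends on the free carboxylic acid itself.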